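This account rests on a few compounds, and the source may have more. Where it says the series, first, only, none or still open, it means among the compounds named here.

Compound 2 `C[C@@H]1CN(c2sc(C(F)(F)F)nc2-c2nc3ccccc3[nH]2)CCN1C(=O)Cn1cccn1` and compound 1 `COC1CCN(CC(=O)N2CCN(c3sc(C(F)(F)F)nc3-c3nc4ccccc4[nH]3)C[C@H]2C)C1` share one core and differ only in the group on the saturated chain carbon bound to the carbonyl carbon. In a functional assay on Venous blood for antagonist activity at C-X-C chemokine receptor type 3 (Homo sapiens), read by flow cytometry, with a stated time of 30 min, in the presence of a further agent that is not named here (on this read-out higher numbers stand for weaker inhibition and lower numbers for stronger inhibition), compound 2 gives 191 nM, the lowest of the two numbers recorded so far. In this assay compound 1 gives 3380 nM. Among the compounds with values here, the only measured step, an 18-fold lower number from compound 1 to compound 2 (1.25 log units; beyond the scatter), shows that exchanging 3-methoxypyrrolidin-1-yl for 1H-pyrazol-1-yl at that position moves the number strongly downward.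

Compound 3 `C[C@@H]1CN(c2sc(C(F)(F)F)nc2-c2nc3ccccc3[nH]2)CCN1C(=O)CN1CCC(F)(F)CC1` is the next member of the series. Its change from compound 2 is 4,4-difluoropiperidin-1-yl in place of 1H-pyrazol-1-yl on a saturated chain carbon bound to a carbonyl carbon. The step from compound 1 to compound 2 bears on this directly: it went from a saturated nitrogen ring to the five-membered aromatic ring, and compound 3 reverses that kind of move, returning to a saturated six-membered nitrogen ring that carries two fluorines. On that basis the step is expected to run in the opposite direction, and for compound 3 the expected change in this assay is a 7.9-fold higher number from compound 2 to compound 3 (0.90 log units; beyond the scatter). Compound 3 is therefore estimated at 1500 nM, within a range from 400 nM to 5000 nM.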

Compound 3, half-maximal inhibitory concentration: 2430 nM
The estimate for compound 3 lay 1.6-fold (0.21 log units) below the measured number; the range from low to high includes it.
By their numbers in this assay, from the lowest: compound 2; then compounds 3 and 1 (each within the scatter of the next).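

In this assay, the low number of compound 2 does not survive a return to a saturated nitrogen ring: a 13-fold higher number from compound 2 to compound 3 (1.10 log units; beyond the scatter) is a large step of about the same size as the earlier one, although the group that enters is 4,4-difluoropiperidin-1-yl rather than 3-methoxypyrrolidin-1-yl. The two saturated rings cannot be told apart at this position, since a 1.4-fold lower number from compound 1 to compound 3 (0.14 log units; within the scatter) stays within the scatter, so among these three compounds the 1H-pyrazol-1-yl group alone stands apart, and neither the methoxy group nor the two fluorines separates compound 1 from compound 3. No measurement is at hand that would explain why this position responds in this way.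

The compounds shown leave open whether the gain belongs to aromatic rings at this position in general or to 1H-pyrazol-1-yl in particular, which a group such as 1H-imidazol-1-yl or 1H-1,2,4-triazol-1-yl on the same chain carbon would test against compound 2 at 191 nM. They also leave open how a plain piperidin-1-yl or a morpholin-4-yl group would compare with compound 3.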